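Furan-3-yl Replacing 3-Cyanophenyl on the Cyclopropane Ring

The source may report more compounds than this note shows. Statements on the series, on what has been measured and on what is new or still open speak of the compounds shown alone.

Compound 3 `CC[C@H](C)[C@H](N)CN(C(=O)[C@@H]1C[C@H]1c1cccc(C#N)c1)c1ccc(-c2ccccc2)cc1` stands highest among the three numbers recorded in a functional assay for agonist activity at G protein-coupled receptor 88 (Homo sapiens), read by HTRF and cAMP accumulation (a higher number here means that more compound is needed for the effect, a lower number that less compound is needed), at 1600 nM. Compound 1 `CC[C@H](C)[C@@H](CN(C(=O)[C@@H]1C[C@H]1c1ccccc1)c1ccc(-c2ccccc2)cc1)NC(C)=O` gives 5.8 nM and compound 2 `CC(C)C[C@H](N)CCN(C(=O)[C@@H]1C[C@H]1c1ccccc1)c1ccc(-c2ccccc2)cc1` gives 3 nM. Within the data shown here, the single measured step, a 1.9-fold lower number from compound 1 to compound 2 (0.29 log units; within the scatter), sits on the chain bound to the amide-type nitrogen and does not touch the three-membered ring. Compound 4 `CC[C@H](C)[C@H](N)CN(C(=O)[C@@H]1C[C@H]1c1ccoc1)c1ccc(-c2ccccc2)cc1` differs from compound 3 by furan-3-yl in place of 3-cyanophenyl on a saturated ring carbon. Among the measured compounds shown here, no measured step bears on that place; the data show only that compounds 1 and 2, which carry neither of these two groups, sit far below compound 3. The step of an 8.0-fold lower number from compound 3 to compound 4 (0.90 log units; beyond the scatter) is therefore expected, tentatively, to move toward a lower number. Compound 4 is estimated at 200 nM, with a range from 20 nM to 2000 nM.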

Compound 4, half-maximal effective concentration: 580 nM
Beside the measured number, compound 4's estimate is 2.9-fold (0.46 log units) below it, and the stated range covers the measured number.
By their numbers in this assay, from the lowest: compounds 2 and 1 (each within the scatter of the next); then compound 4; then compound 3.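

At the saturated ring carbon of the three-membered ring, this assay now gives its first measured step, a 2.8-fold lower number from compound 3 to compound 4 (0.44 log units; beyond the scatter). The group held at this place therefore bears on the number, and a five-membered aromatic ring with one hetero atom is tolerated there in place of 3-cyanophenyl. No measurement shown gives a cause for this step.

On these data alone, it remains open whether the step follows from losing the nitrile or from changing the ring. Plain phenyl on the chain of compound 3 would separate these two, and thiophen-3-yl would test the ring oxygen.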